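The source may hold more compounds than are shown below. What is called first, only, known or untested is meant among the compounds shown, and "the series" means these compounds.

Measured so far in an ADME assay on a cell-free system (plasma, Homo sapiens) for protein binding:
- compound 1 `CO[C@H](C)c1c(NC(=O)Nc2cnc(-n3nccn3)c(Cl)c2)cnc2cc(Cl)nn12`: 97.7%
- compound 2 `O=C(Nc1cnc(-n2nccn2)c(Cl)c1)Nc1cnc2cc(Cl)nn2c1C1CC1`: > 99% (a limit, not a number)
- compound 3 `O=C(Nc1cnc(-n2nccn2)c(Cl)c1)Nc1cnc2cc(Cl)nn2c1C1CCOCC1`: 98.8%

Among the measured compounds shown here, the only step beyond the scatter that touches compound 1 is an at least 2.3-fold lower unbound fraction from compound 1 to compound 2 (0.36 log units; beyond the scatter). The other, a 1.9-fold lower unbound fraction from compound 1 to compound 3 (0.28 log units; within the scatter), stays within the scatter, so compound 1 and compound 3 cannot be told apart on these numbers. The remaining pair gives an at least 1.2-fold higher unbound fraction from compound 2 to compound 3 (0.07 log units; that floor lies within the scatter). One caution applies at the top of the range: the limit of > 99% in this assay, at which 1 of the 3 values shown sits.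

Next is compound 4 `COCc1c(NC(=O)Nc2cnc(-n3nccn3)c(Cl)c2)cnc2cc(Cl)nn12`, with the change (hydrogen in place of methyl on a saturated chain carbon bound to an aromatic carbon and an oxygen on a saturated carbon). In words, this is hydrogen in place of methyl on a saturated chain carbon bound to an aromatic carbon and an oxygen on a saturated carbon, or 1-methoxyethyl to methoxymethyl. For the measured compounds named here, no measured step removes this methyl alone. The nearest evidence is the two replacements of the whole 1-methoxyethyl group, in compound 2 and compound 3, and these are far larger edits. Even so, a 1.9-fold lower unbound fraction from compound 1 to compound 3 (0.28 log units; within the scatter) did not leave the scatter and an at least 2.3-fold lower unbound fraction from compound 1 to compound 2 (0.36 log units; beyond the scatter) left it only modestly. A smaller edit is therefore expected to give no step beyond the scatter in this assay. The expected outcome is a 1.2-fold higher unbound fraction from compound 1 to compound 4 (0.09 log units; within the scatter). For compound 4 the estimate is 97.2%, with an expected range of 95.5% to 98.6%.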

Compound 4, plasma protein binding: 98.1%
Estimate against measurement, compound 4: 1.5-fold (0.17 log units) (unbound fraction) above, and the stated range covers the measured number.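

In this assay, among the compounds shown here, this is the first edit at this position that takes out only the methyl on the saturated chain carbon, leaving the methoxy group in place, and it gives a 1.2-fold lower unbound fraction from compound 1 to compound 4 (0.08 log units; within the scatter). The methyl can therefore go without a readable change in this read-out, so 1-methoxyethyl and methoxymethyl cannot be told apart here. Swapping the whole group for oxan-4-yl gives a 1.6-fold higher unbound fraction from compound 3 to compound 4 (0.20 log units; within the scatter), which means that no pair among compound 1, compound 3 and compound 4 leaves the scatter, while the comparison with the cyclopropyl analogue starts from a limit and not a number, so an at least 1.9-fold higher unbound fraction from compound 2 to compound 4 (0.27 log units; that floor lies within the scatter) is a floor only: the limit of > 99% in this assay, at which 1 of the 4 values shown sits.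

As far as these compounds go, all of these values sit close together near the top of the range, so what a primary amine or a carboxylic acid on this aromatic carbon would do to the unbound fraction remains open. From the compounds shown here alone, a longer chain such as 2-methoxyethyl, and the opposite configuration of 1-methoxyethyl, also stay open, and with them the question of whether any edit at this position moves the read-out clearly toward more free compound.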